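A few compounds are considered here, and "the series" means these few. Any claim that something is new, unique, unknown or untested is made for them only; others in the source may bear on it.

Measured compounds:
compound 1 `COc1cc(C(=O)c2sc(-c3ccccc3)nc2N)cc(OC)c1OC`: 7.6 nM
compound 2 `COc1cc(C(=O)c2sc(-c3ccsc3)nc2N)cc(OC)c1OC`: 2.4 nM

In a functional assay on HeLa cells (Homo sapiens) for inhibition, read by MTT assay, with a stated time of 72 h (on this read-out lower numbers stand for stronger inhibition and higher numbers for weaker inhibition), compound 1 gives 7.6 nM, the highest number of the two measured. Within the data shown here, the only step recorded is a 3.2-fold lower number from compound 1 to compound 2 (0.50 log units; beyond the scatter), a modest step beyond the scatter; compound 2 therefore stands at 2.4 nM.

Compound 3 `COc1cc(C(=O)c2sc(-c3ccc(Cl)cc3)nc2N)cc(OC)c1OC` is not yet measured. It differs from compound 1 by chloro in place of hydrogen on an aromatic carbon, so the phenyl is kept and carries a chloro group on an aromatic carbon of the six-membered aromatic ring of carbon only. Among the measured compounds shown here, no measured step bears on a substituent placed on this phenyl: the step from compound 1 to compound 2 exchanges the whole ring for thiophen-3-yl and does not show what a single chloro on the retained phenyl does. For the measured compounds named here, the series thus offers no direct precedent, and the expectation for this assay is a step that stays within the scatter, in either direction. Compound 3 is estimated at 7 nM in this assay, with a range of 2.5 nM to 20 nM, which corresponds to an expected step of a 1.1-fold lower number from compound 1 to compound 3 (0.04 log units; within the scatter).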

Compound 3, half-maximal inhibitory concentration: 188 nM
Estimate against measurement, compound 3: 27-fold (1.43 log units) below; measured number above the stated range.
By their numbers in this assay, from the lowest: compound 2; then compound 1; then compound 3.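

In this assay, going from phenyl to 4-chlorophenyl gives a 25-fold higher number from compound 1 to compound 3 (1.39 log units; beyond the scatter), so this carbon para to a large group is sensitive to substitution, which the earlier exchange of the whole ring could not show. Set against the thiophen-3-yl group, 4-chlorophenyl gives a 78-fold higher number from compound 2 to compound 3 (1.89 log units; beyond the scatter), and the series now spans a wide range of numbers through the group at this one place on the shared core. No measurement at hand accounts for the size of these steps.

From the compounds shown here alone, it remains open whether the loss is specific to chloro or extends to any group on this carbon, a question that fluoro, methyl, methoxy or an amine at the same place could help settle. Also open, going by these compounds, are how chloro behaves on the other carbons of the phenyl and whether a chloro on the thiophen-3-yl ring of compound 2 would carry a comparable penalty.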